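Macrocyclic motilin receptor ligands: replacing the hydroxyphenyl group

The source may hold more compounds than are shown below. What is called first, only, known or untested is meant among the compounds shown, and "the series" means these compounds.

Measured compounds:
- compound 1 `CCC[C@@H]1NC(=O)[C@@H](CCC(=O)O)NC(=O)[C@@H](Cc2ccc(O)cc2)NCCOc2ccccc2/C=C/CNC1=O`: 4900 nM
- compound 2 `CCC[C@@H]1NC(=O)[C@@H](C(C)C)NC(=O)[C@@H](Cc2ccc(O)cc2)NCCCc2ccccc2/C=C\CCNC1=O`: 7300 nM
- compound 3 `CCC[C@@H]1NC(=O)[C@@H](C(C)C)NC(=O)[C@@H](Cc2ccc(O)cc2)NCCOc2ccccc2CCCNC1=O`: 55 nM

In an assay on isolated protein for displacement of a labelled ligand from Motilin receptor (Homo sapiens) (on this read-out higher numbers stand for weaker inhibition and lower numbers for stronger inhibition), compound 3 gives the lowest number of the three, and its gap to compound 1 and to compound 2 lies well beyond the scatter. Compound 4 `CCC[C@@H]1NC(=O)[C@@H](C(C)C)NC(=O)[C@@H](CC2CCCCC2)NCCOc2ccccc2CCCNC1=O` is not yet measured. It differs from compound 3 by cyclohexyl in place of 4-hydroxyphenyl on a saturated chain carbon bound to a saturated ring carbon. Within the data shown here, no measured pair shows this change, so its size can only be guessed. Compound 4 is expected to lose some binding relative to compound 3, with an estimated step of a 3.1-fold higher number from compound 3 to compound 4 (0.49 log units; beyond the scatter) in this assay, a change beyond the scatter but leaving compound 4 clearly tighter than compound 1 or compound 2. The expected value for compound 4 is 170 nM, with a range from 40 nM to 800 nM.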

Compound 4, inhibition constant: 3250 nM
Beside the measured number, compound 4's estimate is 19-fold (1.28 log units) below it; measured number outside the range, above it.
By their numbers in this assay, from the lowest: compound 3; then compounds 4, 1 and 2 (each within the scatter of the next, the first and the last beyond it).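

In this assay cyclohexyl in place of 4-hydroxyphenyl on a saturated chain carbon bound to a saturated ring carbon gives a 59-fold higher number from compound 3 to compound 4 (1.77 log units; beyond the scatter) and shows that binding at this position depends strongly on the group that leaves. The aromatic ring and its hydroxyl leave together in this one step, so their shares in the loss cannot be separated. Nothing measured on hand accounts for the size of this loss.

Open, as far as these compounds go, is whether plain phenyl or 4-methoxyphenyl would hold the binding of compound 3. A 4-aminophenyl group at this position also remains an open case.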